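The compounds below may be only part of what the source reports. "The series", "measured", "known", "first", "only" and "open" are said of these compounds alone.

Measured compounds:
compound 1 `CC(C)(C)COC(=O)N1CCC(Oc2ncnc3c2CCN3c2ccc(S(C)(=O)=O)cc2F)CC1` with 39.8 nM;
compound 2 `CSC(=O)N1CCC(Oc2ncnc3c2CCN3c2ccc(S(C)(=O)=O)cc2F)CC1` with 251 nM;
compound 3 `CCS(=O)(=O)N1CCC(Oc2ncnc3c2CCN3c2ccc(S(C)(=O)=O)cc2F)CC1` with 1580 nM.

In a functional assay on CHO-K1 cells for agonist activity at Glucose-dependent insulinotropic receptor (Homo sapiens), read by a luciferase reporter, with a stated time of 5 h (a lower number here means that less compound is needed, a higher number that more compound is needed for the effect), compound 3 carries the highest number of the three; compound 2 lies nearest, a 6.3-fold higher number from compound 2 to compound 3 (0.80 log units; beyond the scatter), and compound 1 furthest, a 40-fold higher number from compound 1 to compound 3 (1.60 log units; beyond the scatter). Compound 4 `CS(=O)(=O)c1ccc(N2CCc3c(OC4CCN(C5=NCCCN5)CC4)ncnc32)c(F)c1` has not been measured in this assay. It differs from compound 3 in one place: a group of 6 heavy atoms (4 carbon, 2 nitrogen; one six-membered non-aromatic ring with 2 hetero atoms) in place of a group of 5 heavy atoms (2 carbon, 2 oxygen, 1 sulfur; no ring), on an amine nitrogen in a ring. Within the data shown here, no measured step exchanges a group of this kind, so the two steps that bear on the question are those that alter the group on the same ring nitrogen, a 40-fold higher number from compound 1 to compound 3 (1.60 log units; beyond the scatter) and a 6.3-fold higher number from compound 2 to compound 3 (0.80 log units; beyond the scatter), each beyond the scatter and both pointing to a strong dependence of this assay on that position. The direction for a ring group with a hydrogen-bond donor is not fixed by the data. Compound 4 is therefore expected to give 3000 nM, within 700 nM to 13000 nM, a step estimated as a 1.9-fold higher number from compound 3 to compound 4 (0.28 log units; within the scatter).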

Compound 4, half-maximal effective concentration: 2000 nM
Compound 4: the middle estimate sits 1.5-fold (0.18 log units) above what was measured; the range from low to high includes it.
By their numbers in this assay, from the lowest: compound 1; then compound 2; then compounds 3 and 4 (each within the scatter of the next).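

In this assay, the six-membered ring group with its hydrogen-bond donor and the open ethylsulfonyl group on the ring nitrogen cannot be told apart (a 1.3-fold higher number from compound 3 to compound 4 (0.10 log units; within the scatter)), so this exchange of group type brings no change beyond the scatter. The ring group also leaves the gaps to the two carbonyl-bearing groups in place (an 8.0-fold higher number from compound 2 to compound 4 (0.90 log units; beyond the scatter); a 50-fold higher number from compound 1 to compound 4 (1.70 log units; beyond the scatter)), so among these compounds, neither it nor the ethylsulfonyl group reaches the number seen with neopentyloxycarbonyl. Nothing at hand explains why these groups rank as they do.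

The compounds shown leave open whether an open-chain amine on this nitrogen would fall with compound 3 and compound 4 or closer to compound 1. They also leave open how a longer alkoxycarbonyl chain or a simple acetyl group would compare with neopentyloxycarbonyl.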